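Ethyl for vinyl on the three-membered ring: stability notes

This account rests on a few compounds, and the source may have more. Where it says the series, first, only, none or still open, it means among the compounds named here.

Measured so far in an ADME assay (Rattus norvegicus) for metabolic stability; on this read-out higher numbers stand for a longer-lived compound and lower numbers for a shorter-lived compound:
- compound 1, `COc1ccc2nc3c(nc2c1)O[C@H]1CN(C(=O)[C@H](C(C)(C)C)NC(=O)O[C@@H]2C[C@H]2CCCCC3)[C@H](C(=O)N[C@]2(C(=O)NS(=O)(=O)C3(C)CC3)C[C@H]2C(F)F)[C@@H]1C`: 1.3 h
- compound 2, `CC[C@@H]1[C@@H]2CN(C(=O)[C@H](C(C)(C)C)NC(=O)O[C@@H]3C[C@H]3CCCCCc3nc4ccc(OC)cc4nc3O2)[C@@H]1C(=O)N[C@]1(C(=O)NS(=O)(=O)C2(C)CC2)C[C@H]1C(F)F`: 1.4 h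
- compound 3, `C=C[C@@H]1C[C@]1(NC(=O)[C@@H]1[C@H](CC)[C@@H]2CN1C(=O)[C@H](C(C)(C)C)NC(=O)O[C@@H]1C[C@H]1CCCCCc1nc3ccc(OC)cc3nc1O2)C(=O)NS(=O)(=O)C1CC1`: 2.2 h

Compound 3 gives the highest of the three numbers in this assay, but its gaps to compound 2 and to compound 1 both sit within the usual scatter, so the three compounds cannot be separated on this read-out.

Compound 4, `CC[C@@H]1[C@@H]2CN(C(=O)[C@H](C(C)(C)C)NC(=O)O[C@@H]3C[C@H]3CCCCCc3nc4ccc(OC)cc4nc3O2)[C@@H]1C(=O)N[C@]1(C(=O)NS(=O)(=O)C2CC2)C[C@H]1CC`, is not yet measured. Its change from compound 3 is ethyl in place of vinyl on a saturated ring carbon.

Going by the values given here, the only single-point step measured is a small alkyl change elsewhere in the molecule, a 1.1-fold higher number from compound 1 to compound 2 (0.03 log units; within the scatter). Among the compounds with values here, no measured step touches the saturated ring carbon of the three-membered non-aromatic ring of carbon only, and no measured pair exchanges vinyl for ethyl. Within the data shown here, the one step available was within the scatter, and the present change is of similar size. Compound 4 is therefore expected to give a number close to that of compound 3, with the estimated step of a 1.1-fold lower number from compound 3 to compound 4 (0.04 log units; within the scatter) staying within the scatter.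

For compound 4 the estimate in this assay is 2 h, with a range from 1.1 h to 3.6 h.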

Compound 4, half-life: 5 h
Compound 4: middle estimate off by 2.5-fold (0.40 log units), on the low side; measured number outside the range, above it.
By their numbers in this assay, from the lowest: compounds 1, 2 and 3 (each within the scatter of the next); then compound 4.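

In this assay, ethyl in place of vinyl on a saturated ring carbon of the three-membered non-aromatic ring gives a 2.3-fold higher number from compound 3 to compound 4 (0.36 log units; beyond the scatter), the only step shown that lies beyond the scatter, whereas the single earlier step, at another place, gave a 1.1-fold higher number from compound 1 to compound 2 (0.03 log units; within the scatter). The two groups hold the same 2 heavy atoms and differ in the one double bond, so this place responds to a change that leaves the heavy-atom count untouched. No measurement shown gives a reason for the step.

From the compounds shown here alone, whether a longer chain such as propyl on the same ring carbon moves the half-life further remains open. Also open, going by these compounds, is whether a cyclopropyl group or an amine at this place would hold the number reached by compound 4.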